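The compounds below may be only part of what the source reports. "The series", "measured", "known", "first", "only" and "open" are said of these compounds alone.

In a functional assay on BT-474 cells (Homo sapiens) for cytotoxicity, read by MTT assay, with a stated time of 48 h (a lower number here means a stronger inhibitor, a higher number a weaker inhibitor), compound 3 `O=C(/C=C\Nc1ccc(Cl)cc1)c1nc(-c2ccc(C(F)(F)F)cc2)n2ccccc12` gives 3820 nM, the lowest of the two numbers shown. Compound 1 `O=C(/C=C\Nc1ccc(F)cc1)c1nc(-c2ccc(F)cc2)n2ccccc12` gives 16900 nM in this assay. Compound 2 `COc1ccc(N/C=C\C(=O)c2nc(-c3ccc(C(F)(F)F)cc3)n3ccccc23)cc1OC` gives only a limit in this assay, > 30000 nM. Among the compounds with values here, the one measured step on the amine side, an at least 7.8-fold lower number from compound 2 to compound 3 (0.89 log units; beyond the scatter), is the only step bearing on the change to compound 4 `O=C(/C=C\Nc1ccc(F)cc1)c1nc(-c2ccc(C(F)(F)F)cc2)n2ccccc12`, which is fluoro in place of chloro on an aromatic carbon. Compound 1 carries the same 4-fluorophenyl amine as compound 4 but a different group on the other aryl ring, so its gap to compound 3 cannot be assigned to the amine side alone. A moderate rise in number is expected, a 2.4-fold higher number from compound 3 to compound 4 (0.37 log units; beyond the scatter), with compound 4 estimated at 9000 nM, between 3500 nM and 25000 nM.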

Compound 4, half-maximal inhibitory concentration: > 30000 nM
Compound 4 gave a limit, no number; the forecaster's own chance of this, stated with the estimate: 10%; middle value at least 3.3-fold (0.52 log units) away from the limit.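

In this assay compound 4 gives > 30000 nM, which is a limit of the assay and not a number. Fluoro in place of chloro on an aromatic carbon is therefore not a silent exchange on the amine side: an at least 7.8-fold higher number from compound 3 to compound 4 (0.89 log units; beyond the scatter). The trifluoromethyl change on the other aryl ring gives an at least 1.7-fold higher number from compound 1 to compound 4 (0.24 log units; that floor lies within the scatter), a floor too small to resolve that change, and the remaining step, with limits at both ends, cannot be read.

How far compound 2 and compound 4 lie past the limit stays unknown: the limit of > 30000 nM in this assay, at which 2 of the 4 values shown sit.

On these data alone, whether bromo or methyl at this position retains the activity of compound 3 remains open.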